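A few compounds are considered here, and "the series" means these few. Any claim that something is new, unique, unknown or untested is made for them only; others in the source may bear on it.

Compound 1 `O=C(CCCCC1CCSS1)Nc1ccccc1Cl`: in a functional assay on HO8910 cells (Homo sapiens) for inhibition, read by MTT assay, with a stated time of 24 h, tested at 0.1 ug/mL (a lower number here means less inhibition of growth, a higher number more inhibition of growth at the concentration tested), compound 1 gives 8.17%.
Compound 2 `O=C(CCCCC1CCSS1)Nc1cccc2ccccc12`: in this assay compound 2 gives 0.34%.
Compound 3 `O=C(CCCCC(S)CCS)Nc1ccccc1Cl`: in this assay compound 3 gives 6.11%.

Compound 3 differs from compound 1 in one place only: a group of 5 heavy atoms (3 carbon, 2 sulfur; no ring) in place of a group of 5 heavy atoms (3 carbon, 2 sulfur; one five-membered non-aromatic ring with 2 hetero atoms), on a saturated chain carbon, four bonds along the chain from a carbonyl carbon. The resulting step, a number 2.1 percentage points lower from compound 1 to compound 3 (within the scatter), lies within the scatter, so the two values cannot be told apart. Compound 2 carries a different core; how the cores of compound 1 and compound 2 differ is not broken down here. All three measured values lie within the scatter of one another. Compound 4 `O=C(CCCCC(S)CCS)Nc1cccc2ccccc12` has not yet been measured. It arises from compound 2 by the same change made from compound 1 to compound 3, namely (a group of 5 heavy atoms (3 carbon, 2 sulfur; no ring) in place of a group of 5 heavy atoms (3 carbon, 2 sulfur; one five-membered non-aromatic ring with 2 hetero atoms), on a saturated chain carbon, four bonds along the chain from a carbonyl carbon), at the same place. The step from compound 2 to compound 4 is expected to be small, a number 0.3 percentage points lower from compound 2 to compound 4 (within the scatter), because a number 2.1 percentage points lower from compound 1 to compound 3 (within the scatter) stayed within the scatter. For compound 4 in this assay the expected value is 0%, with a range from -8% to 8%.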

Compound 4, percent growth inhibition at one concentration: 0.76%
The estimate for compound 4 lay 0.8 percentage points below the measured number; the measured number falls inside the stated range.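

In this assay, putting 1,3-disulfanylpropyl in place of the five-membered non-aromatic ring, on the same saturated chain carbon, gives a number 0.4 percentage points higher from compound 2 to compound 4 (within the scatter). Set beside the earlier step, the change looks the same on both cores: the same change on two cores in this assay, a number 2.1 percentage points lower (within the scatter) from compound 1 to compound 3 and a number 0.4 percentage points higher (within the scatter) from compound 2 to compound 4, 2.5 percentage points apart, within the scatter of two such steps. Going by these compounds alone, this shows that the change produced no step beyond the scatter on either core, but it does not show that the two groups are equivalent, as the reading comes from one cell line at one concentration and covers only two cores.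

The compounds shown leave open how an amine or a carboxylic acid in that place would read in this assay, and whether a longer chain would matter. They also leave open whether the two groups would still match at higher concentrations.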